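The source may hold more compounds than are shown below. What is called first, only, known or untested is meant among the compounds shown, and "the series" means these compounds.

Measured in a functional assay on HL-60 cells (Homo sapiens) for cytotoxicity, read by MTT assay, with a stated time of 72 h; a higher number here means a weaker inhibitor, a lower number a stronger inhibitor:
- Compound 1 `COC(=O)c1sc2cc(OC)ccc2c1Nc1cc(OC)c(OC)c(OC)c1`: 0.4 nM
- Compound 2 `CCOC(=O)c1sc2ccccc2c1Nc1cc(OC)c(OC)c(OC)c1`: 5490 nM
- Compound 3 `CCOC(=O)c1sc2cc(C)ccc2c1Nc1cc(OC)c(OC)c(OC)c1`: 3.9 nM

Going by the values given here, of these three numbers, the one for compound 3 is the second highest, lying well above that of compound 1 and far below that of compound 2. The next analogue, compound 4 `CCOC(=O)c1sc2cc(OC)ccc2c1Nc1cc(OC)c(OC)c(OC)c1`, keeps the ethyl ester of compound 3 and carries methoxy in place of methyl on an aromatic carbon.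

Among the compounds with values here, the only measured single change at this carbon is methyl in place of hydrogen, a 1400-fold lower number from compound 2 to compound 3 (3.15 log units; beyond the scatter), a large step. It shows that this carbon matters, but it does not compare methyl with methoxy. Compound 1 has methoxy here but a methyl ester, and it gives 0.4 nM. Within the data shown here, no measured pair isolates the ester change, so this is only a loose guide to a lower number.

A modest move downward is therefore expected, a 2.6-fold lower number from compound 3 to compound 4 (0.41 log units; beyond the scatter). For compound 4 the estimated value is 1.5 nM, with an expected range of 0.3 nM to 10 nM.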

Compound 4, half-maximal inhibitory concentration: 31.6 nM
For compound 4 the middle estimate is 21-fold (1.32 log units) below the measured one; measured number above the stated range.
By their numbers in this assay, from the lowest: compound 1; then compound 3; then compound 4; then compound 2.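

In this assay, methoxy in place of methyl on this aromatic carbon gives an 8.1-fold higher number from compound 3 to compound 4 (0.91 log units; beyond the scatter) with the ethyl ester held fixed, so of the two groups, methyl gives the lower number. Methoxy still keeps a large advantage over hydrogen at this carbon, giving a 170-fold lower number from compound 2 to compound 4 (2.24 log units; beyond the scatter) as the ethyl ester stays unchanged. The ester also proves to matter in its own right: with methoxy on the ring, methyl in place of hydrogen on the saturated chain carbon bound to an oxygen next to a carbonyl group gives a 79-fold higher number from compound 1 to compound 4 (1.90 log units; beyond the scatter) as a large step.

No available evidence accounts for these differences. Going by these compounds, it remains open how an amine or a fluorine on this carbon would compare, and how a methyl ester would behave with methyl on the ring.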